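Amino for methyl on the pyridyl of compound 1

The source may report more compounds than this note shows. Statements on the series, on what has been measured and on what is new or still open speak of the compounds shown alone.

In an assay for binding affinity to metabotropic glutamate receptor 5 (Rattus norvegicus) (a higher number here means a weaker inhibitor, a lower number a stronger inhibitor), compound 1 `Cc1cnccc1-c1cc(F)cc(-n2nnc(-c3ccccn3)n2)c1` gives 33 nM, the lower of the two numbers in hand, though the gap to compound 2 is within the scatter. Compound 2 `Cc1ccc(-c2cc(F)cc(-n3nnc(-c4ccccn4)n3)c2)cn1` gives 36 nM in this assay, and the step of a 1.1-fold higher number from compound 1 to compound 2 (0.04 log units; within the scatter) shows that this position tolerates a rearranged methylpyridyl group without effect beyond the scatter. Compound 3 `Nc1ccncc1-c1cc(F)cc(-n2nnc(-c3ccccn3)n2)c1` differs from compound 1 by 4-aminopyridin-3-yl in place of 3-methylpyridin-4-yl on an aromatic carbon. Among the compounds with values here, the only measured step at this position, a 1.1-fold higher number from compound 1 to compound 2 (0.04 log units; within the scatter), swapped one methylpyridyl for another; no measured pair covers an amino group here, so its effect is unknown and the range must be wide. Compound 3 is expected to move by a 1.8-fold higher number from compound 1 to compound 3 (0.26 log units; within the scatter) in this assay, a step that may not exceed the scatter. Compound 3 is estimated at 60 nM, between 20 nM and 180 nM.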

Compound 3, inhibition constant: 20 nM
Compound 3: middle estimate off by 3.0-fold (0.48 log units), on the high side; the measured number falls inside the stated range.
By their numbers in this assay, from the lowest: compounds 3, 1 and 2 (each within the scatter of the next).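

In this assay, the steps of a 1.7-fold lower number from compound 1 to compound 3 (0.22 log units; within the scatter) and a 1.8-fold lower number from compound 2 to compound 3 (0.26 log units; within the scatter) widen what this position is known to tolerate: the earlier pair carried only methylpyridyl groups, whereas 4-aminopyridin-3-yl has 1 hydrogen-bond donor against 0 for 3-methylpyridin-4-yl and stays level with both. Swapping methyl for amino on the pyridyl ring thus gives no change beyond the scatter, and the three compounds cannot be ranked in this assay. No supporting data on hand explain this tolerance.

Open, as far as these compounds go, is whether this position accepts a ring other than pyridyl, such as a plain phenyl ring. Equally open, from the compounds shown here alone, is whether a larger substituent on the pyridyl ring, such as a dimethylamino group or a longer alkyl chain, would keep the number level.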